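Moving two chlorines: from compound 3 to compound 4

The compounds below may be only part of what the source reports. "The series", "measured", "known", "first", "only" and "open" are said of these compounds alone.

compound 1 `COc1ccc(/C=C2\CCC/C(=C\c3ccc(Cl)cc3)C2=O)cc1OC` gives 4800 nM
compound 2 `COc1ccc(/C=C2\CCC/C(=C\c3ccc(Br)cc3)C2=O)cc1OC` gives 4300 nM
compound 3 `COc1ccc(/C=C2\CCC/C(=C\c3ccc(Cl)cc3Cl)C2=O)cc1OC` gives 10500 nM

In a functional assay on HT-1080 cells (Homo sapiens) for cytotoxicity, read by MTT assay, with a stated time of 72 h (a lower number here means a stronger inhibitor, a higher number a weaker inhibitor), compound 3 stands highest of the three, and its number of 10500 nM marks the weakest inhibitor here. Compound 4 `COc1ccc(/C=C2\CCC/C(=C\c3cc(Cl)cc(Cl)c3)C2=O)cc1OC` has the same atoms joined differently (3,5-dichlorophenyl in place of 2,4-dichlorophenyl on a double-bonded chain carbon bound to a double-bonded ring carbon) on the same double-bonded chain carbon. Among the compounds with values here, two measured steps bear on this. Exchanging the halogen gave a 1.1-fold lower number from compound 1 to compound 2 (0.05 log units; within the scatter) while the added chloro gave a 2.2-fold higher number from compound 1 to compound 3 (0.34 log units; beyond the scatter) as the only modest rise of its kind, alongside a 2.4-fold higher number from compound 2 to compound 3 (0.39 log units; beyond the scatter) for the related change. Within the data shown here, no measured step shows chlorines changing place, so the evidence is thin. A small estimated move toward a lower number, a 1.5-fold lower number from compound 3 to compound 4 (0.18 log units; within the scatter), is expected. Compound 4 is expected to read 7000 nM within an estimated range of 2800 nM to 15000 nM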

Compound 4, half-maximal inhibitory concentration: 3000 nM
Beside the measured number, compound 4's estimate is 2.3-fold (0.37 log units) above it; measured number inside the range.
By their numbers in this assay, from the lowest: compounds 4, 2 and 1 (each within the scatter of the next); then compound 3.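

In this assay the same two chlorines set as 3,5-dichlorophenyl instead of 2,4-dichlorophenyl gave a 3.5-fold lower number from compound 3 to compound 4 (0.54 log units; beyond the scatter) and so showed that at this position their arrangement counts, not only their presence. A second chlorine as such need not raise the number: a 1.4-fold lower number from compound 2 to compound 4 (0.16 log units; within the scatter) and a 1.6-fold lower number from compound 1 to compound 4 (0.20 log units; within the scatter) leave only compound 3 apart. Nothing measured here gives a reason for this. The compounds shown leave open whether an amine or a carboxylic acid in place of the chlorines would read alike, and whether a single chlorine placed elsewhere on this ring would follow compound 3 or compound 4.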